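The source may report more compounds than this note shows. Statements on the series, on what has been measured and on what is new or still open speak of the compounds shown alone.

Measured compounds and their numbers in the series:

compound 1 `C[C@]1(O)C[C@@](c2ccnc(C(F)(F)F)c2)([C@H](O)c2ccccn2)C1` — in an ADME assay on liver for metabolic stability, with Liver microsome (Rattus norvegicus) as the target, read by LC-MS, using microsomes, with a stated time of 5 h (on this read-out lower numbers stand for slow clearance and higher numbers for fast clearance), compound 1 gives 50 mL/min/kg
compound 2 `O[C@H](c1ccccn1)[C@]1(c2cccc(OC(F)(F)F)c2)C[C@H](O)C1` — in this assay compound 2 gives 117 mL/min/kg

Of the two numbers, compound 1 stands lowest; the nearest is compound 2, whose number is higher by a gap that falls beyond the scatter. For the measured compounds named here, no step between measured compounds differing in one place is available.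

Compound 3 `C[C@]1(O)C[C@](c2ccnc(C(F)(F)F)c2)([C@H](O)c2ccccn2)C1` is not yet measured. Its difference from compound 1: the two compounds have the same atoms and bonds and differ only in configuration as drawn: 2 of 3 stereo elements differ; a stereocentre at a saturated ring carbon is drawn R in compound 1 and S in compound 3; a stereocentre at a saturated ring carbon is drawn s in compound 1 and r in compound 3. Nothing leaves and nothing enters; only the drawn configuration of the ring changes.

Going by the values given here, with no measured pair of this kind to lean on, the expectation for compound 3 is a step of modest size from compound 1, most likely staying within the scatter, with no firm direction; a slightly higher number is taken as somewhat more probable than a lower one. The estimated step is a 1.2-fold higher number from compound 1 to compound 3 (0.08 log units; within the scatter). For compound 3 the expected clearance in this assay is 60 mL/min/kg, with a range from 30 mL/min/kg to 120 mL/min/kg.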

Compound 3, clearance: 83.3 mL/min/kg
Compound 3: middle estimate off by 1.4-fold (0.14 log units), on the low side; measured number inside the range.
By their numbers in this assay, from the lowest: compounds 1, 3 and 2 (each within the scatter of the next, the first and the last beyond it).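

This is the only pair shown that isolates a single kind of change: the fact that compounds 1 and 3 differ only in the configuration as drawn. In this assay, the step is a 1.7-fold higher number from compound 1 to compound 3 (0.22 log units; within the scatter), so at this position the read-out does not separate the two drawn configurations of the saturated ring carbons. For this substitution pattern, the configuration change therefore has no effect on clearance that can be told from the usual scatter.

Going by these compounds, whether this holds for other groups remains open, for example with an amine or a carboxylic acid at the saturated ring carbon in place of the groups in compound 1 and compound 3. On these data alone, the effect of the third stereo element, which is the same in both compounds, also remains open.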